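Trimming the Aryl Ether: Forecast for Compound 4

A few compounds are considered here, and "the series" means these few. Any claim that something is new, unique, unknown or untested is made for them only; others in the source may bear on it.

Compound 1, `N#Cc1ccc(Nc2nc(Oc3ccccc3Cl)c3ccccc3n2)cc1`, gives 38000 nM
Compound 2, `Cc1cc(Br)c(Oc2nc(Nc3ccc(C#N)cc3)nc3ccccc23)c(Br)c1`, gives 25000 nM
Compound 3, `Cc1cc(C#N)cc(C)c1Oc1nc(Nc2ccc(C#N)cc2)nc2ccccc12`, gives 203000 nM

These three compounds share one core and differ only in the aryl group carried on the ether oxygen; all were tested in an ADME assay on MT4 cells (Homo sapiens) for cytotoxicity, read by MTT assay, with a stated time of 4 days; a lower number here means that less compound is tolerated, a higher number that more compound is tolerated. Compound 3 stands highest of the three: the step of a 5.3-fold higher number from compound 1 to compound 3 (0.73 log units; beyond the scatter) and the step of an 8.1-fold higher number from compound 2 to compound 3 (0.91 log units; beyond the scatter) both lie beyond the scatter, whereas compound 1 and compound 2 sit within the scatter of each other, as the step of a 1.5-fold lower number from compound 1 to compound 2 (0.18 log units; within the scatter) shows.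

Compound 4, `N#Cc1ccc(Nc2nc(Oc3ccccc3)c3ccccc3n2)cc1`, awaits measurement. It differs from compound 3 in one place: phenyl in place of 4-cyano-2,6-dimethylphenyl on an oxygen on an aromatic ring. The two steps that bear on this change are the ones leading into compound 3, each a modest rise when a halogenated phenyl was exchanged for the 4-cyano-2,6-dimethylphenyl group. Compound 4 undoes that group entirely, leaving a bare phenyl that most resembles the 2-chlorophenyl of compound 1. A modest fall back toward the value of compound 1 is therefore expected. For compound 4 the expected step is a 5.1-fold lower number from compound 3 to compound 4 (0.71 log units; beyond the scatter). Compound 4 is estimated at 40000 nM, with a range from 15000 nM to 110000 nM.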

Compound 4, half-maximal cytotoxic concentration: 370000 nM
For compound 4 the middle estimate is 9.3-fold (0.97 log units) below the measured one; measured number outside the range, above it.
By their numbers in this assay, from the lowest: compounds 2 and 1 (each within the scatter of the next); then compounds 3 and 4 (each within the scatter of the next).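

In this assay, the plain phenyl and the 4-cyano-2,6-dimethylphenyl group on the ether oxygen cannot be told apart (a 1.8-fold higher number from compound 3 to compound 4 (0.26 log units; within the scatter)), so the nitrile and the two methyl groups are not required for a number in this upper range. The clearest new finding comes from a single atom: hydrogen in place of chloro on an aromatic carbon gives a 9.7-fold higher number from compound 1 to compound 4 (0.99 log units; beyond the scatter), and the plain phenyl also stands well clear of the 2,6-dibromo-4-methylphenyl group (a 15-fold higher number from compound 2 to compound 4 (1.17 log units; beyond the scatter)). Across these four compounds, the two aryl groups carrying a halogen give the lower numbers and the two without one give the higher numbers, with no compound going against that split, yet no measurement here accounts for it.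

Four compounds cannot show whether the split follows halogens in general, and a phenyl carrying a single fluoro, a single methyl or a methoxy group would test this more directly. From the compounds shown here alone, it also remains open how the tolerated concentration would respond to an amine or a carboxylic acid on this ring, or to a change elsewhere on the shared core.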